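A few compounds are considered here, and "the series" means these few. Any claim that something is new, unique, unknown or untested is made for them only; others in the source may bear on it.

Of the compounds shown here, two built on one shared core have been measured in a functional assay on the whole organism (strain Wistar) for inhibition, with Rattus norvegicus as the target, read by paw edema, with stated times of 30 min and 120 min, at a dose of 50 mg/kg by the oral route; on this read-out lower numbers stand for less inhibition and higher numbers for more inhibition at the one dose given (going by the name of the read-out). Compound 1 `CC(=O)N1N=C(c2ccc(Cl)cc2)CC1c1cn(-c2ccccc2)nc1-c1ccc(Cl)c(Cl)c1` carries an acetyl group on the ring nitrogen, and in this assay compound 1 gives 66.4%. Compound 2 `Clc1ccc(C2=NN(c3ccccc3)C(c3cn(-c4ccccc4)nc3-c3ccc(Cl)c(Cl)c3)C2)cc1` carries a phenyl group at that position instead, and in this assay compound 2 gives 61.7%. The step between them is a number 4.7 percentage points lower from compound 1 to compound 2 (within the scatter). On the numbers shown, compound 2 holds the smaller figure, but the gap to compound 1 is within the scatter, so no ordering can be read from it.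

Compound 3 `CCC(=O)N1N=C(c2ccc(Cl)cc2)CC1c1cn(-c2ccccc2)nc1-c1ccc(Cl)c(Cl)c1` has not yet been measured. It differs from compound 2 in a single place: propanoyl in place of phenyl on an amine nitrogen in a ring. Among the measured compounds shown here, the only measured step that bears on this change is the one from acetyl to phenyl at the same position, which was a number 4.7 percentage points lower from compound 1 to compound 2 (within the scatter), within the scatter. Propanoyl resembles acetyl far more than it resembles phenyl, so compound 3 is expected to sit close to compound 1 and within reach of compound 2. The step of a number 3.3 percentage points higher from compound 2 to compound 3 (within the scatter) is expected to remain within the scatter. Compound 3 is therefore estimated at 65%, with a range from 52% to 78%.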

Compound 3, a percentage reported as inhibition, in the whole organism at one dose (the size of the read-out at that dose, not a potency): 68.8%
Estimate against measurement, compound 3: 3.8 percentage points below, and the stated range covers the measured number.
By their numbers in this assay, from the lowest: compounds 2, 1 and 3 (each within the scatter of the next).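

In this assay the change from phenyl to propanoyl on the amine nitrogen in the ring gives a number 7.1 percentage points higher from compound 2 to compound 3 (within the scatter) and so, like the earlier step from acetyl to phenyl, leaves the read-out within the scatter, even though a carbon-only aromatic ring is exchanged for a ring-free chain with a carbonyl. Extending the chain of the acetyl group by one methyl, a smaller change than any seen before at this position, gives a number 2.4 percentage points higher from compound 1 to compound 3 (within the scatter) and so also cannot be told apart from no change, which means that acetyl, phenyl and propanoyl are all accommodated at this position with no ordering among the three compounds. Nothing at hand explains why this position responds so little to these changes.

The compounds shown do not tell whether this flat picture would hold for a plain hydrogen on that nitrogen, for a longer chain such as butanoyl, or for a chain ending in an amine or a carboxylic acid. They also leave open whether the three groups would separate at any dose other than the single one used here.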